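Solubility of a Shared Core with a Pyrrolidinyl Side Chain

The compounds below may be only part of what the source reports. "The series", "measured", "known", "first", "only" and "open" are said of these compounds alone.

Compound 1 `Cc1cc(NCc2ccncc2)n2nc(C)c(-c3ccccc3)c2n1`: 134000 nM
Compound 2 `Cc1cc(NCc2ccccn2)n2nc(C)cc2n1`: > 200000 nM

For the measured compounds named here, in a physicochemical assay for solubility, read by HPLC, using the shake flask method, measured as kinetic solubility, with a stated time of 2 h, at pH 7.4 (on this read-out lower numbers stand for lower solubility and higher numbers for higher solubility), compound 1 gives 134000 nM, the only number that this set contains. Going by the values given here, compound 2 is reported only as a limit of the assay, > 200000 nM, and this is the one point where a value sits at the limit of > 200000 nM in this assay, at which 1 of the 2 values shown sits. Compound 2 differs from compound 1 in more than one place, so its limit and the number of compound 1 can only be set side by side.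

Compound 3 `CCN1CCCC1CNc1cc(C)nc2c(-c3ccccc3)c(C)nn12` has not yet been measured. It differs from compound 1 by 1-ethylpyrrolidin-2-yl in place of pyridin-4-yl on a saturated chain carbon bound to a nitrogen on an aromatic ring. Among the compounds with values here, no step between measured compounds exists to guide the expectation, so the direction and size of the change remain open; a change within the usual scatter is a reasonable starting point, though a rise toward the limit of this assay cannot be excluded. Compound 3 is estimated at 180000 nM, with a range from 80000 nM to 200000 nM, which means an expected step of a 1.3-fold higher number from compound 1 to compound 3 (0.13 log units; within the scatter).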

Compound 3, solubility: 172000 nM
Compound 3: middle estimate off by 1.0-fold (0.02 log units), on the high side; the measured number falls inside the stated range.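

In this assay, for the compounds shown here, putting 1-ethylpyrrolidin-2-yl in place of pyridin-4-yl on a saturated chain carbon bound to a nitrogen on an aromatic ring gives the first step that can be read at this position: a 1.3-fold higher number from compound 1 to compound 3 (0.11 log units; within the scatter). This single pair shows that a five-membered non-aromatic ring and a six-membered aromatic ring, each with 1 hetero atom, can stand at this place on the shared core with the read-out staying within the scatter. Compound 3 gives a number that can be compared with that of compound 1, whereas compound 2 remains a limit of the assay: the limit of > 200000 nM in this assay, at which 1 of the 3 values shown sits.

The compounds shown leave open whether a primary amine, a carboxylic acid or a morpholine ring at this place would also stay within the scatter. They also leave open whether the same exchange would read alike on another core.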